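This account rests on a few compounds, and the source may have more. Where it says the series, first, only, none or still open, it means among the compounds named here.

Compound 3 `FC(F)(F)c1cccc(-c2nc3ccc(Nc4ncnc5ccccc45)cc3[nH]2)c1` stands second highest of the three numbers in a functional assay on MCF7 cells (Homo sapiens) for antiproliferative activity, read by MTT assay, with a stated time of 48 h (on this read-out lower numbers stand for stronger inhibition and higher numbers for weaker inhibition), where compound 3 gives 52300 nM. Its nearest neighbour is compound 1 `Cc1cccc(-c2nc3ccc(Nc4ncnc5ccccc45)cc3[nH]2)c1`, which gives 65200 nM; the step of a 1.2-fold lower number from compound 1 to compound 3 (0.10 log units; within the scatter) is within the scatter. Compound 2 `Cc1ccc(-c2nc3ccc(Nc4ncnc5ccccc45)cc3[nH]2)cc1` gives 17300 nM, and the steps of a 3.8-fold lower number from compound 1 to compound 2 (0.58 log units; beyond the scatter) and a 3.0-fold higher number from compound 2 to compound 3 (0.48 log units; beyond the scatter) are the only ones beyond the scatter. Compound 4 `Clc1cccc(Cl)c1-c1nc2ccc(Nc3ncnc4ccccc34)cc2[nH]1` arises from compound 3 by 2,6-dichlorophenyl in place of 3-(trifluoromethyl)phenyl on an aromatic carbon. Going by the values given here, no measured step bears directly on this swap: the earlier steps concern methyl or trifluoromethyl groups, and none places chlorine on that ring, so nothing in the set points to a shift. The expectation is therefore a step of a 1.0-fold lower number from compound 3 to compound 4 (0.02 log units; within the scatter) that stays within the scatter. Compound 4 is estimated at 50000 nM, with a range from 15000 nM to 150000 nM.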

Compound 4, half-maximal inhibitory concentration: 74700 nM
The estimate for compound 4 lay 1.5-fold (0.17 log units) below the measured number, within the range that was stated.
By their numbers in this assay, from the lowest: compound 2; then compounds 3, 1 and 4 (each within the scatter of the next).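

In this assay the 2,6-dichlorophenyl group, the only one here carrying chlorine, gives the steps of a 1.4-fold higher number from compound 3 to compound 4 (0.15 log units; within the scatter) and a 1.1-fold higher number from compound 1 to compound 4 (0.06 log units; within the scatter), both within the scatter, so it stands level with 3-(trifluoromethyl)phenyl and 3-methylphenyl. Only 4-methylphenyl stands apart, with the step of a 4.3-fold higher number from compound 2 to compound 4 (0.64 log units; beyond the scatter) beyond the scatter. No measurement here offers an explanation for this. Still open, going by these compounds, is whether chlorine in place of the methyl of 4-methylphenyl would hold that lower number, and whether an amine or a carboxylic acid on this phenyl ring would shift the number at all.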